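Nitro Substitution on the Anilino Ring of Compound 1

The compounds below may be only part of what the source reports. "The series", "measured", "known", "first", "only" and "open" are said of these compounds alone.

Measured compounds:
compound 1 `c1ccc(Nc2ccc(N3CC4CC(C3)N4)nn2)cc1`, 441 nM
compound 2 `CN(c1ccccc1)c1ccc(N2CC3CC(C2)N3)nn1`, 1430 nM

In an assay on cell membranes for displacement of a labelled ligand from Neuronal acetylcholine receptor; alpha4/beta2 (Rattus norvegicus) (a lower number here means a stronger inhibitor, a higher number a weaker inhibitor), compound 1 gives 441 nM, the lowest of the two numbers, while compound 2 gives 1430 nM. Among the measured compounds shown here, the one step between them, a 3.2-fold higher number from compound 1 to compound 2 (0.51 log units; beyond the scatter), concerns methyl in place of hydrogen on a nitrogen on an aromatic ring. Compound 3 `O=[N+]([O-])c1ccc(Nc2ccc(N3CC4CC(C3)N4)nn2)cc1` differs from compound 1 by nitro in place of hydrogen on an aromatic carbon, a change on the carbocyclic ring rather than at the nitrogen. For the measured compounds named here, no measured step bears on substitution of that ring, so the single step recorded offers no direct guide. With nothing to point either way, compound 3 is expected to give 350 nM, within 100 nM to 1300 nM, a step of a 1.3-fold lower number from compound 1 to compound 3 (0.10 log units; within the scatter) that is estimated to stay near the scatter.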

Compound 3, inhibition constant: 86.2 nM
For compound 3 the middle estimate is 4.1-fold (0.61 log units) above the measured one; measured number outside the range, below it.
By their numbers in this assay, from the lowest: compound 3; then compound 1; then compound 2.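

In this assay, among the compounds shown here, the only earlier step, at the nitrogen, raised the number, whereas this one shows that the carbocyclic ring can take a substituent and lower it. Nitro in place of hydrogen on an aromatic carbon, para to a large group, gives a 5.1-fold lower number from compound 1 to compound 3 (0.71 log units; beyond the scatter) and leaves the hydrogen on the nitrogen in place. Nothing shown accounts for this gain.

With a single substituent at a single place, the compounds shown leave open whether the gain is specific to nitro or would also appear with an amine, a nitrile or a carboxylic acid in that position. They also leave open how the same group would fare elsewhere on the ring, and whether methyl on the nitrogen would raise the number of compound 3 as it did for compound 1.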